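Trading a Pyrrolidine for a Cyclopropyl on the Pyridine

The compounds below may be only part of what the source reports. "The series", "measured", "known", "first", "only" and "open" are said of these compounds alone.

Of the compounds shown here, two that share one core have been tested in an assay on T-REx-293 cells for inhibition of potassium channel subfamily T member 1 (Homo sapiens), read by patch clamp; a lower number here means a stronger inhibitor, a higher number a weaker inhibitor. Compound 1 `C[C@H](NC(=O)c1cc(C(F)(F)F)nn1C)c1nc(-c2cnn(C)c2)no1` gives 2640 nM. Compound 2 `C[C@H](NC(=O)c1cc(C(F)(F)F)nn1C)c1nc(-c2ccnc(N3CCCC3)c2)no1` gives 573 nM, the lower of the two numbers, and the gap between compound 2 and compound 1 lies well beyond the usual scatter, so compound 2 is the stronger inhibitor of the pair. Compound 3 `C[C@H](NC(=O)c1cc(C(F)(F)F)nn1C)c1nc(-c2ccnc(C3CC3)c2)no1` keeps everything of compound 2 except one group: cyclopropyl in place of pyrrolidin-1-yl on an aromatic carbon. Within the data shown here, no measured pair here reports such a swap, so its effect has to be judged from the bare change alone. The expectation is a modest rise in the number, with a step from compound 2 to compound 3 of about a 1.7-fold higher number from compound 2 to compound 3 (0.24 log units; within the scatter) in this assay, a step that may not clear the scatter. Compound 3 is therefore estimated at 1000 nM in this assay, within a range of 300 nM to 3000 nM.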

Compound 3, half-maximal inhibitory concentration: 16 nM
Estimate against measurement, compound 3: 63-fold (1.80 log units) above; measured number outside the range, below it.
By their numbers in this assay, from the lowest: compound 3; then compound 2; then compound 1.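

The aromatic carbon next to the ring nitrogen proves highly sensitive to what it carries: in this assay, cyclopropyl in place of pyrrolidin-1-yl gives a 36-fold lower number from compound 2 to compound 3 (1.55 log units; beyond the scatter), even though the entering group has fewer heavy atoms and no hydrogen-bond acceptor. Exchanging the whole 1-methyl-1H-pyrazol-4-yl for 2-cyclopropylpyridin-4-yl gives a 170-fold lower number from compound 1 to compound 3 (2.22 log units; beyond the scatter), the widest gap among these compounds. Nothing measured here explains why this change has such an effect.

This one swap changes ring size and removes a nitrogen at the same time, so the two changes cannot be told apart. On these data alone, how a cyclobutyl, an isopropyl or a dimethylamino group would compare at this carbon remains open, as does whether the cyclopropyl gain would hold with a different group elsewhere on the shared core.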